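Removing a Fluorine Ortho to Methylpiperazine

This account rests on a few compounds, and the source may have more. Where it says the series, first, only, none or still open, it means among the compounds named here.

Of the compounds shown here, two sharing one core have been measured in an assay on HeLa cells for inhibition of activin receptor type-1 (Homo sapiens), read by HTRF, with stated times of 1 h and 30 min; on this read-out higher numbers stand for weaker inhibition and lower numbers for stronger inhibition. Compound 1, `COC(=O)N1C[C@@H](C)N(c2ncc3[nH]nc(-c4ccc(N5CCN(C)CC5)c(F)c4)c3n2)[C@@H](C)C1`, gives 119 nM. Compound 2, `COC(=O)N1C[C@@H](C)N(c2ncc3[nH]nc(-c4ccc(N5CCN[C@H](C)C5)nc4)c3n2)[C@@H](C)C1`, gives 27 nM. Of these two numbers compound 1 holds the higher one, and the gap to compound 2 lies beyond the usual scatter of repeated measurements. Compound 2 differs from compound 1 in more than one place, so its value shows only where a related structure can land, not what any single change does.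

Compound 3, `COC(=O)N1C[C@@H](C)N(c2ncc3[nH]nc(-c4ccc(N5CCN(C)CC5)cc4)c3n2)[C@@H](C)C1`, is not yet measured. It differs from compound 1 in one place: hydrogen in place of fluoro on an aromatic carbon. Within the data shown here, no measured pair shows this change on its own, so its effect is unknown here. Compound 3 is expected to give about 110 nM, within a range from 40 nM to 300 nM. This estimate means an expected step of a 1.1-fold lower number from compound 1 to compound 3 (0.03 log units; within the scatter) that stays within the scatter, in no firm direction.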

Compound 3, half-maximal inhibitory concentration: 61 nM
Beside the measured number, compound 3's estimate is 1.8-fold (0.26 log units) above it; the range from low to high includes it.
By their numbers in this assay, from the lowest: compound 2; then compounds 3 and 1 (each within the scatter of the next).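

In this assay, hydrogen in place of fluoro on this aromatic carbon, ortho to a 4-methylpiperazin-1-yl group, gives a 2.0-fold lower number from compound 1 to compound 3 (0.29 log units; within the scatter). This is the first pair to isolate the change, and it shows that removing this single fluorine leaves the two compounds indistinguishable on this read-out, so this fluoro is not shown to matter here. Nothing available explains the size of this step or identifies any role for the fluoro.

What a chloro group, a methoxy group or an amine on this same carbon would do remains open, since hydrogen and fluoro are the only two substituents shown here. Also open, as far as these compounds go, is whether swapping hydrogen for fluoro would give a similar step on a compound carrying a different piperazine group.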